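Difluoromethyl in place of trifluoromethyl: solubility outlook

The source may report more compounds than this note shows. Statements on the series, on what has been measured and on what is new or still open speak of the compounds shown alone.

Compound 1 `C[C@@H]1CN(c2c(C#N)c(C(F)(F)F)nn2-c2ccc(S(C)(=O)=O)cn2)[C@H](C)CO1` carries a trifluoromethyl group on its core. In a physicochemical assay for solubility (on this read-out lower numbers stand for lower solubility and higher numbers for higher solubility), compound 1 reaches the limit of the measurement, > 200 ug/mL. Compound 2 `C[C@@H]1CN(c2c(C#N)c(C(F)F)nn2-c2ccc(S(C)(=O)=O)cn2)[C@H](C)CO1` differs from it by hydrogen in place of fluoro on a saturated chain carbon bound to an aromatic carbon and two fluorine atoms. In this assay compound 2 likewise sits at the limit, > 200 ug/mL. The step that the two limits leave unreadable from compound 1 to compound 2 can therefore not be read, since both values stand at the limit of > 200 ug/mL in this assay, at which 2 of the 3 values shown sit, and the assay reports no number above it.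

Compound 3 `CC1CCCN(c2c(C#N)c(C(F)(F)F)nn2-c2ccc(S(C)(=O)=O)cc2)C1` has a different core; how that core differs from the core of compound 1 is not broken down here. In this assay compound 3 is recorded as "not determined" (no result reported), so no number exists for it. Compound 4 `CC1CCCN(c2c(C#N)c(C(F)F)nn2-c2ccc(S(C)(=O)=O)cc2)C1` is derived from compound 3 by hydrogen in place of fluoro on a saturated chain carbon bound to an aromatic carbon and two fluorine atoms. This is the same change that leads from compound 1 to compound 2, at the same place on the molecule.

Among the compounds with values here, of the two measured members of this change, compound 1 sits at the limit, > 200 ug/mL. Compound 2 also sits at the limit, > 200 ug/mL. The size of the step therefore cannot be taken from them, and the core of compound 3 has no measured value to anchor an expectation. The estimate for compound 4 in this assay therefore rests only on the observation that the change left compound 1 and compound 2 at the limit. Compound 4 is expected to give about 110 ug/mL, with a plausible range from 30 ug/mL to 200 ug/mL.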

Compound 4, solubility: 50 ug/mL
Compound 4: middle estimate off by 2.2-fold (0.34 log units), on the high side; the measured number falls inside the stated range.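

In this assay compound 4 gives 50 ug/mL while compound 3 stands as "not determined" (no result reported) so no step can be read between compound 3 and compound 4, and the pair of compound 1 and compound 2 stays unreadable too: the limit of > 200 ug/mL in this assay, at which 2 of the 4 values shown sit.

The compounds shown leave open how far trifluoromethyl to difluoromethyl moves the read-out in this assay on either core.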